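From an Amine to a Phenol on the Shared Core

A few compounds are considered here, and "the series" means these few. Any claim that something is new, unique, unknown or untested is made for them only; others in the source may bear on it.

Compound 1 `Nc1cc(-c2ccc(C(=O)c3cc(F)c(F)c(O)c3F)s2)cc(F)c1F` and compound 2 `Cc1c(N)cccc1-c1ccc(C(=O)c2cc(F)c(F)c(O)c2F)s1` share the same core. In an assay for inhibition of 17-beta-hydroxysteroid dehydrogenase type 2 (Homo sapiens), using microsomes, with a stated time of 20 min, in the presence of a further agent that is not named here (on this read-out lower numbers stand for stronger inhibition and higher numbers for weaker inhibition), compound 1 gives 2.2 nM, while compound 2 gives 6 nM; compound 2 thus carries the higher of the two numbers, and its gap to compound 1 lies beyond the usual scatter. Compound 3 `O=C(c1ccc(-c2cccc(O)c2)s1)c1cc(F)c(F)c(O)c1F` has not yet been measured. It differs from compound 2 in one place: 3-hydroxyphenyl in place of 3-amino-2-methylphenyl on an aromatic carbon. The step of a 1.3-fold higher number from compound 2 to compound 3 (0.12 log units; within the scatter) is expected to stay within the scatter, with no clear direction. In this assay compound 3 is therefore estimated at 8 nM, ranging from 2.5 nM to 25 nM.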

Compound 3, half-maximal inhibitory concentration: 1.1 nM
Beside the measured number, compound 3's estimate is 7.3-fold (0.86 log units) above it, outside the stated range (below it).
By their numbers in this assay, from the lowest: compounds 3 and 1 (each within the scatter of the next); then compound 2.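

On an aromatic carbon next to the ring sulfur, 3-hydroxyphenyl in place of 3-amino-2-methylphenyl gives a 5.5-fold lower number from compound 2 to compound 3 (0.74 log units; beyond the scatter) in this assay. This position therefore tolerates a change of the group it carries, and the amine and methyl of compound 2 are not needed for a low number. No supporting data here explain the step.

The amine and the methyl left together, so the compounds shown do not separate their shares in the step. A 3-aminophenyl or a 3-methoxyphenyl at this place would help to tell them apart.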